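The compounds below may be only part of what the source reports. "The series", "measured", "known", "first", "only" and "open" are said of these compounds alone.

Measured in a functional assay on A2780 cells (Homo sapiens) for inhibition, read by MTT assay, with a stated time of 72 h; a lower number here means a stronger inhibitor, a higher number a weaker inhibitor:
- compound 1 `O=C1/C(=C\c2ccccc2)c2c(ncn2COCc2ccccc2)CCN1Cc1ccccc1`: 20400 nM
- compound 2 `O=C1/C(=C\c2ccccc2)c2c(ncn2COCc2ccccc2)CCN1Cc1ccc(-c2ccccc2)cc1`: 48300 nM
- compound 3 `Cc1ccccc1CN1CCc2ncn(COCc3ccccc3)c2/C(=C/c2ccccc2)C1=O`: 25300 nM

Compound 3 lies within the scatter of both others: a 1.2-fold higher number from compound 1 to compound 3 (0.09 log units; within the scatter), and a 1.9-fold lower number from compound 2 to compound 3 (0.28 log units; within the scatter).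

Compound 4 `CC(C)(C)c1ccc(CN2CCc3ncn(COCc4ccccc4)c3/C(=C/c3ccccc3)C2=O)cc1` carries 4-(tert-butyl)phenyl in place of 2-methylphenyl on a saturated chain carbon bound to an amide-type nitrogen in a ring.

Within the data shown here, the closest precedent is the other substitution at the 4-position of this aryl group, a 2.4-fold higher number from compound 1 to compound 2 (0.37 log units; beyond the scatter), which is modest and goes toward a higher number. The methyl step above stayed within the scatter. A small move toward a higher number in this assay is therefore expected, estimated as a 1.4-fold higher number from compound 3 to compound 4 (0.14 log units; within the scatter).

Compound 4 is estimated at 35000 nM, with an expected range of 16000 nM to 70000 nM.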

Compound 4, half-maximal inhibitory concentration: 23900 nM
Beside the measured number, compound 4's estimate is 1.5-fold (0.17 log units) above it; the measured number falls inside the stated range.
By their numbers in this assay, from the lowest: compounds 1, 4, 3 and 2 (each within the scatter of the next, the first and the last beyond it).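

In this assay, tert-butyl on the aromatic carbon stays within the scatter of both hydrogen (a 1.2-fold higher number from compound 1 to compound 4 (0.07 log units; within the scatter)) and the 2-methylphenyl arrangement (a 1.1-fold lower number from compound 3 to compound 4 (0.02 log units; within the scatter)). Tert-butyl in place of phenyl gives a modest step beyond the scatter (a 2.0-fold lower number from compound 2 to compound 4 (0.31 log units; beyond the scatter)), so the higher number of compound 2 goes with phenyl and not with every substituent at this place. No evidence on the cause bears on this result. From the compounds shown here alone, whether an amine or a carboxylic acid on this aromatic ring would give a clearly lower number remains open.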